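A Methoxy Group Added to a Weak Pyrazolopyridine Inhibitor

The compounds below may be only part of what the source reports. "The series", "measured", "known", "first", "only" and "open" are said of these compounds alone.

Of the compounds shown here, two have been measured so far in a functional assay on MCF7 cells (Homo sapiens) for inhibition, read by MTT assay, with a stated time of 48 h; on this read-out lower numbers stand for stronger inhibition and higher numbers for weaker inhibition. Compound 1 `O=C(C=CNc1cc(-c2ccccc2)nn1-c1ccccc1)c1ccccc1` gives 9650 nM in this assay. Compound 2 `c1ccc(-c2ccnc3c2c(-c2ccccc2)nn3-c2ccccc2)cc1`, built on a different core, gives 28200 nM in this assay, which is the higher of the two numbers, so compound 2 stands as the weaker of the pair, and the gap between compound 2 and compound 1 lies beyond the usual scatter. Among the compounds with values here, no step between these two measured compounds can be described, since they differ in more than one place.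

Compound 3 `COc1ccc(-c2ccnc3c2c(-c2ccccc2)nn3-c2ccccc2)cc1` keeps the whole framework of compound 2 and changes it in one spot: methoxy in place of hydrogen on an aromatic carbon. The change is small, adding a methoxy group with one hydrogen-bond acceptor and no ring, on the aromatic carbon para to a large group.

Within the data shown here, nothing among the measured compounds tells how such a methoxy group shifts the number in this assay. The account therefore expects for compound 3 a step of a 1.3-fold lower number from compound 2 to compound 3 (0.11 log units; within the scatter), which amounts to no change beyond the scatter. The estimate for compound 3 in this assay is 22000 nM, within a range from 7000 nM to 65000 nM.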

Compound 3, half-maximal inhibitory concentration: 28700 nM
Compound 3: middle estimate off by 1.3-fold (0.12 log units), on the low side, within the range that was stated.
By their numbers in this assay, from the lowest: compound 1; then compounds 2 and 3 (each within the scatter of the next).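

Methoxy in place of hydrogen on an aromatic carbon, para to a large group, gives a 1.0-fold higher number from compound 2 to compound 3 (0.01 log units; within the scatter) in this assay and thus provides the first one-place step in this series. At this position, phenyl and 4-methoxyphenyl cannot be told apart on this read-out, so the added oxygen and carbon leave compound 3 within the scatter of compound 2, something the earlier pair, which differed in more than one place, could not show. No independent measurement bears on why the step is so small, so this single comparison establishes only the size of the step and offers no explanation for it.

The compounds shown leave open whether a different group at this same position, such as an amine, a carboxylic acid or a longer chain like butoxy, would give a step beyond the scatter. They also leave open whether methoxy would give a similar step on the other phenyl rings of this framework, or on the core of compound 1.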